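Bromo to 1-Methylethenyl on an Aromatic Carbon

This account rests on a few compounds, and the source may have more. Where it says the series, first, only, none or still open, it means among the compounds named here.

Measured so far:
compound 1, `Cc1c(C(=O)Nc2ccc(Oc3ncnc4[nH]cc(-c5ccccc5)c34)c(F)c2)c(=O)c2cc(Br)ccc2n1C`: 3120 nM
compound 2, `CCc1ccc2c(c1)c(=O)c(C(=O)Nc1ccc(Oc3ncnc4[nH]cc(-c5ccccc5)c34)cc1)c(C)n2C`: 105 nM

In an assay on isolated protein for inhibition of tyrosine-protein kinase receptor UFO (Homo sapiens), read by FRET and Z'-LYTE, with a stated time of 1.5 h (a higher number here means a weaker inhibitor, a lower number a stronger inhibitor), compound 1 stands at the highest of the two numbers; compound 2 gives the lower number, and that gap lies beyond the scatter. Going by the values given here, compound 3, `C=C(C)c1ccc2c(c1)c(=O)c(C(=O)Nc1ccc(Oc3ncnc4[nH]cc(-c5ccccc5)c34)c(F)c1)c(C)n2C`, is not yet measured. 1-methylethenyl in place of bromo on an aromatic carbon No step between measured compounds isolates this change, so the expectation rests on the high number of compound 1 and the lower number of compound 2. For compound 3 a moderate step toward a lower number, beyond the scatter, is expected a 3.9-fold lower number from compound 1 to compound 3 (0.59 log units; beyond the scatter). The estimate for compound 3 is 800 nM, with a range from 250 nM to 2500 nM.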

Compound 3, half-maximal inhibitory concentration: 170 nM
Beside the measured number, compound 3's estimate is 4.7-fold (0.67 log units) above it, and the stated range ends above it.
By their numbers in this assay, from the lowest: compounds 2 and 3 (each within the scatter of the next); then compound 1.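

In this assay, going by these compounds alone, 1-methylethenyl in place of bromo on an aromatic carbon gives an 18-fold lower number from compound 1 to compound 3 (1.26 log units; beyond the scatter), the only step here that isolates this position. With the rest of compound 1 unchanged, the group on this carbon alone accounts for a large change in the number. No available evidence explains this step. From the compounds shown here alone, whether the gain follows the double bond outside the aromatic rings or the carbon atoms themselves stays open. An isopropyl group, a longer chain or an amine on this carbon would bear on that.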